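A few compounds are considered here, and "the series" means these few. Any claim that something is new, unique, unknown or untested is made for them only; others in the source may bear on it.

Measured so far:
- compound 1 `CC1CCN(C2CCN(S(=O)(=O)c3cccnc3Cl)CC2)CC1` gives, in a functional assay on DLD-1 cells (Homo sapiens) for antiproliferative activity, read by CellTiter-Glo, with a stated time of 72 h (a lower number here means a stronger inhibitor, a higher number a weaker inhibitor), a limit of the assay: > 5000 nM
- compound 2 `Cc1nc(Cl)sc1S(=O)(=O)N1CCC(N2CCC(C)CC2)CC1` gives in this assay 1.6 nM

Going by the values given here, compound 2 stands as the only compound with a number in this assay; the other value is a limit (the limit of > 5000 nM in this assay, at which 1 of the 2 values shown sits). The step from compound 1 to compound 2 is an at least 3100-fold lower number from compound 1 to compound 2 (3.49 log units; beyond the scatter), which shows that the group on the sulfonyl sulfur can move the number in this assay a great deal.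

Compound 3 `CCc1ccc(S(=O)(=O)N2CCC(N3CCC(C)CC3)CC2)cc1` has not yet been measured. It differs from compound 2 in this way: 4-ethylphenyl in place of 2-chloro-4-methyl-1,3-thiazol-5-yl on a sulfonyl sulfur. Among the compounds with values here, only the step of an at least 3100-fold lower number from compound 1 to compound 2 (3.49 log units; beyond the scatter) bears on this change, and it tells that an aromatic ring other than 2-chloro-4-methyl-1,3-thiazol-5-yl at this place can give a much higher number. Within the data shown here, no compound with a phenyl at the sulfonyl sulfur is known here, so the size of the step is uncertain. Compound 3 is therefore expected to be weaker than compound 2, with the estimated step of a 160-fold higher number from compound 2 to compound 3 (2.19 log units; beyond the scatter). In this assay compound 3 is estimated at 250 nM, in the range 15 nM to 5000 nM.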

Compound 3, half-maximal inhibitory concentration: > 5000 nM
Compound 3 ended at the assay's limit; the forecaster's own chance of this, stated with the estimate: 20%; middle value at least 20-fold (1.30 log units) away from the limit.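

In this assay, the step is an at least 3100-fold higher number from compound 2 to compound 3 (3.49 log units; beyond the scatter), so replacing 2-chloro-4-methyl-1,3-thiazol-5-yl with 4-ethylphenyl on the sulfonyl sulfur loses the low number just as 2-chloropyridin-3-yl did. A six-membered aromatic ring of carbon only therefore joins the ring carrying a nitrogen in failing to give a readable number, and the step between compound 1 and compound 3 cannot be read. Of the three groups shown at this place, only 2-chloro-4-methyl-1,3-thiazol-5-yl gives a number, while the other two compounds end at a limit: the limit of > 5000 nM in this assay, at which 2 of the 3 values shown sit.

Which part of 2-chloro-4-methyl-1,3-thiazol-5-yl matters remains open, since neither its chlorine nor its methyl has been changed on its own here. As far as these compounds go, it is also open whether a phenyl ring carrying a chlorine or an amine in place of the ethyl would give a readable number.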